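Furanone series: bromo for methyl on the furan ring

This account rests on a few compounds, and the source may have more. Where it says the series, first, only, none or still open, it means among the compounds named here.

Compound 1 `COc1ccc2c(=O)cc(-n3ccc4ccccc43)oc2c1` gives 280 nM in an assay on isolated protein for inhibition of Amine oxidase [flavin-containing] B (Homo sapiens), read by fluorescence, with a stated time of 20 min; on this read-out lower numbers stand for stronger inhibition and higher numbers for weaker inhibition.
Compound 2 `COc1ccc2c(c1)C/C(=C\c1ccc(C)o1)C2=O` gives 26 nM in this assay.
Compound 3 `COc1ccc2c(=O)cc(-n3cnc4ccccc43)oc2c1` gives 270 nM in this assay.

Among the compounds with values here, compound 2 has the lowest number of the three and is the most potent compound measured so far: its gaps to compound 3 and to compound 1 both lie beyond the scatter, while compound 1 and compound 3 sit within the scatter of each other. Within the data shown here, compound 1 and compound 3 share a core different from that of compound 2, so no single-point step between measured compounds exists in this set.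

The next compound, compound 4 `COc1ccc2c(c1)C/C(=C\c1ccc(Br)o1)C2=O`, is the 5-bromofuran-2-yl analogue of compound 2. The change is bromo in place of methyl on an aromatic carbon. Nothing in the measured set shows what this exchange does, so the expectation rests on the potency of compound 2 alone. The step of a 1.2-fold higher number from compound 2 to compound 4 (0.06 log units; within the scatter) is expected to stay within the scatter, with no clear direction. Compound 4 is therefore estimated at 30 nM, in the range 10 nM to 100 nM, in this assay.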

Compound 4, half-maximal inhibitory concentration: 4.4 nM
Compound 4: middle estimate off by 6.8-fold (0.83 log units), on the high side, and the stated range ends above it.
By their numbers in this assay, from the lowest: compound 4; then compound 2; then compounds 3 and 1 (each within the scatter of the next).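

Within the data shown here, the only single-point step so far is a 5.9-fold lower number from compound 2 to compound 4 (0.77 log units; beyond the scatter) in this assay, for the change from 5-methylfuran-2-yl to 5-bromofuran-2-yl. It shows that potency responds to the group on this aromatic carbon next to the ring oxygen, even though methyl and bromo each count one heavy atom and neither has a hydrogen-bond donor or acceptor. No measurement on hand explains the size or direction of this step.

Among these compounds, with only two groups compared at this position, no trend can be drawn, and it remains open where chloro, iodo, trifluoromethyl or nitrile would fall relative to compound 4 at 4.4 nM. Also open, from the compounds shown here alone, is whether the exchange would give a similar step with other changes elsewhere on the shared core.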